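Chloro for methoxy on a weakly cytotoxic compound

A few compounds are considered here, and "the series" means these few. Any claim that something is new, unique, unknown or untested is made for them only; others in the source may bear on it.

Measured so far:
- compound 1 `COc1ccccc1/C=c1/[nH]c(=O)/c(=C\c2ccccc2OC)n(C)c1=O` in a functional assay on MCF7 cells (Homo sapiens) for cytotoxicity, read by CCK-8 assay, with a stated time of 72 h (on this read-out higher numbers stand for weaker inhibition and lower numbers for stronger inhibition), gives 9000 nM
- compound 2 `COc1ccccc1/C=c1/[nH]c(=O)/c(=C\c2ccccc2OC)[nH]c1=O` in this assay gives "not active" (no number reported)

Within the data shown here, compound 1 at 9000 nM holds the only number so far in this assay and so has no numerical neighbour to be ranked against. Compound 2 was reported without any number.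

Compound 3 `COc1ccccc1/C=c1\c(=O)[nH]/c(=C/c2ccccc2Cl)c(=O)n1C` has not yet been measured. It departs from compound 1 in one place, 2-methoxyphenyl to 2-chlorophenyl, with chloro in place of methoxy on an aromatic carbon ortho to a large group. Among the measured compounds shown here, no measured pair shows what such an exchange does, so the only anchor is compound 1 at 9000 nM and no step beyond the scatter is expected in either direction in this assay for now. The step of a 1.1-fold lower number from compound 1 to compound 3 (0.05 log units; within the scatter) is accordingly estimated to stay within the usual scatter of this measurement. Compound 3 might also return no number, as compound 2 did. For compound 3 the expected value is 8000 nM with an estimated range from 2500 nM to 25000 nM on this read-out.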

Compound 3, half-maximal inhibitory concentration: 200 nM
Estimate against measurement, compound 3: 40-fold (1.60 log units) above; measured number outside the range, below it.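

In this assay, among these compounds, the exchange of 2-methoxyphenyl for 2-chlorophenyl gives a 45-fold lower number from compound 1 to compound 3 (1.65 log units; beyond the scatter), the first step that can be read. It shows that this place, an aromatic carbon ortho to a large group, is sensitive: a change of one substituent there moves the number well beyond the scatter, which a single number and an entry without a number could not show. No measurement of any property accompanies this step, and the data therefore give no cause for it.

The compounds shown do not tell whether the step depends on chloro itself or would appear with other replacements for methoxy at this place, such as fluoro, bromo, methyl or an amine. They also leave open what the same exchange would do on the second 2-methoxyphenyl, which compound 3 retains, and whether replacing both groups would lower the number further in this assay.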